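A Two-Carbon Insertion Before the Amide Linker

The compounds below may be only part of what the source reports. "The series", "measured", "known", "first", "only" and "open" are said of these compounds alone.

Compound 2 `Nc1ccccc1NC(=O)c1ccc(COCNc2nc(Nc3ccccc3)c3ncn(C4CCCC4)c3n2)cc1` is the stronger of the two measured compounds: in a functional assay on HCT-116 cells (Homo sapiens) for antiproliferative activity, read by CCK-8 assay, with a stated time of 72 h, tested at 2 uM (a higher number here means a stronger effect of the compound at the concentration tested, a lower number a weaker effect), compound 2 gives 75.2%, while compound 1 `Nc1ccccc1NC(=O)/C=C/c1ccc(COCNc2nc(Nc3cccc(Cl)c3)c3ncn(C4CCCC4)c3n2)cc1` gives 9.04% in this assay. Compound 3 `Nc1ccccc1NC(=O)/C=C/c1ccc(COCNc2nc(Nc3ccccc3)c3ncn(C4CCCC4)c3n2)cc1` keeps the core of compound 2 but carries 2-((2-aminophenyl)carbamoyl)ethenyl in place of (2-aminophenyl)carbamoyl on an aromatic carbon. Compound 1 also carries this longer linker, and its low value in this assay leaves room for a fall, although compound 1 differs from compound 3 in a second place as well. A downward step beyond the scatter, a number 40.2 percentage points lower from compound 2 to compound 3 (beyond the scatter), is therefore expected. Compound 3 is estimated at 35%, within 8% to 70%.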

Compound 3, a percentage reported as inhibition, at one concentration (the size of the read-out at that concentration, not a potency): 10.5%
Estimate against measurement, compound 3: 24.5 percentage points above; measured number inside the range.
By their numbers in this assay, from the lowest: compounds 1 and 3 (each within the scatter of the next); then compound 2.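

In this assay, 2-((2-aminophenyl)carbamoyl)ethenyl in place of (2-aminophenyl)carbamoyl gives a number 64.7 percentage points lower from compound 2 to compound 3 (beyond the scatter) as a single change, so this position, para to a large group, does not tolerate the longer linker here. With that linker in place, hydrogen in place of chloro gives a number 1.5 percentage points higher from compound 1 to compound 3 (within the scatter) and the two compounds cannot be told apart. Nothing measured here explains the fall. From the compounds shown here alone, whether a saturated two-carbon chain or a single methylene group before the amide would lose as much remains open. So does the effect of chloro on the shorter linker of compound 2.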